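The source may report more compounds than this note shows. Statements on the series, on what has been measured and on what is new or still open speak of the compounds shown alone.

Of the compounds shown here, two have been measured in a functional assay on HT-29 cells (Homo sapiens) for cytotoxicity, read by MTT assay, with a stated time of 2 days, tested at 10 uM; a higher number here means more inhibition at the concentration tested (going by the name of the read-out), a lower number less inhibition. Compound 1 `Cc1cccc(N2CCN(CCCNc3nc(NCc4ccco4)c4ccccc4n3)CC2)c1C` gives 94%. Compound 2 `c1coc(CNc2nc(NCCCN3CCCC3)nc3ccccc23)c1` gives 87.5%, a number whose gap to compound 1 lies within the scatter, so the two cannot be told apart on these data. Compound 3 `CCN(CC)CCNc1nc(NCc2ccco2)c2ccccc2n1` has not been measured. It differs from compound 2 in one place: diethylamino in place of (pyrrolidin-1-yl)methyl on a saturated chain carbon, two bonds along the chain from a nitrogen on an aromatic ring. Within the data shown here, no step between measured compounds covers this change. In this assay the expected step is a number 2.5 percentage points lower from compound 2 to compound 3 (within the scatter), that is, none beyond the scatter in either direction. For compound 3 the estimate in this assay is 85%, within 70% to 96%.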

Compound 3, a percentage reported as inhibition, at one concentration (the size of the read-out at that concentration, not a potency): 75.1%
Compound 3: middle estimate off by 9.9 percentage points, on the high side, and the stated range covers the measured number.
By their numbers in this assay, from the lowest: compound 3; then compounds 2 and 1 (each within the scatter of the next).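

In this assay, among these compounds, this position responds to the side-chain amine: diethylamino in place of (pyrrolidin-1-yl)methyl gives a number 12.4 percentage points lower from compound 2 to compound 3 (beyond the scatter) and is the only step read so far. The change removes the five-membered non-aromatic ring and, read one bond further out, turns 3-(pyrrolidin-1-yl)propyl into 2-(diethylamino)ethyl, so ring and chain length change together. No measurement available accounts for the step. A 2-(pyrrolidin-1-yl)ethyl or 3-(diethylamino)propyl chain on the same core would separate these two changes. As far as these compounds go, whether a piperidine or morpholine would behave like pyrrolidine remains open.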